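Propoxycarbonyl to benzyloxycarbonyl: a step expected near the limit

The source may report more compounds than this note shows. Statements on the series, on what has been measured and on what is new or still open speak of the compounds shown alone.

Of the compounds shown here, three have been read in a functional assay on HeLa cells (Homo sapiens) for antiproliferative activity, read by MTT assay, with a stated time of 48 h (on this read-out higher numbers stand for weaker inhibition of growth and lower numbers for stronger inhibition of growth), so far. Compound 1 (`COc1cc(C2CC(c3ccccc3)=NN2C(=O)OCc2ccccc2)cc(OC)c1OC`) gives > 10000 nM as a limit of the assay. Compound 2 (`CCOC(=O)N1N=C(c2ccc(OC)cc2)CC1c1cc(OC)c(OC)c(OC)c1`) gives 8710 nM as a measured number. Compound 3 (`CCCOC(=O)N1N=C(c2ccc(OC)cc2)CC1c1cc(OC)c(OC)c(OC)c1`) gives > 10000 nM as a limit, so it has no number of its own. Compound 3 therefore stands at the limit of > 10000 nM in this assay, at which 2 of the 3 values shown sit, in the series.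

The change from compound 3 to compound 4 (`COc1ccc(C2=NN(C(=O)OCc3ccccc3)C(c3cc(OC)c(OC)c(OC)c3)C2)cc1`) is phenyl in place of ethyl on a saturated chain carbon bound to an oxygen next to a carbonyl group and can also be read as propoxycarbonyl to benzyloxycarbonyl. Within the data shown here, the one measured step on this chain is an at least 1.1-fold higher number from compound 2 to compound 3 (0.05 log units; that floor lies within the scatter) and gives only a floor. The benzyloxycarbonyl group also occurs in compound 1, at > 10000 nM as a limit. No step beyond the scatter is therefore expected in this assay, and the estimated step is a number no higher from compound 3 to compound 4 (the limit leaves the size open) with no firm direction. For compound 4 the expected value is 10000 nM (estimated range 4000 nM to 25000 nM) and a report of only a limit is likely.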

Compound 4, concentration for 50% growth inhibition: > 10000 nM
Compound 4: a limit, no number (the forecaster's own chance of this, stated with the estimate: 65%); the middle value sits exactly at the limit.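

In this assay, phenyl in place of ethyl on a saturated chain carbon bound to an oxygen next to a carbonyl group brings in a six-membered aromatic ring, and compound 4 gives > 10000 nM, which is a limit and not a number. The one readable result is an at least 1.1-fold higher number from compound 2 to compound 4 (0.05 log units; that floor lies within the scatter), so phenyl in place of methyl at this place shows only a floor, not a size. The other two steps to compound 4 cannot be read, and the values now gather at one point: the limit of > 10000 nM in this assay, at which 3 of the 4 values shown sit.

As far as these compounds go, how far the number moves above that limit stays unknown for every compound but compound 2. From the compounds shown here alone, whether a group such as an amine, a carboxylic acid or a butyl chain in this place would give a readable number remains open.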